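A Trimethoxybenzoyl Variant of a Sulfonamide Cytotoxic Series

The compounds below may be only part of what the source reports. "The series", "measured", "known", "first", "only" and "open" are said of these compounds alone.

Of the compounds shown here, two have so far been measured in a functional assay on Ehrlich cells (Mus musculus) for cytotoxicity, read by trypan blue exclusion, with a stated time of 2 h; on this read-out lower numbers stand for stronger inhibition and higher numbers for weaker inhibition. Compound 1 `N#CC1=C(N)N(c2ccc(S(N)(=O)=O)cc2)C2=C(C(=O)CCC2)C1c1ccc(Cl)cc1Cl` carries a free amine on the shared core, and in this assay compound 1 gives 25 ug/mL. Compound 2 `N#CC1=C(NC(=O)c2ccccc2)N(c2ccc(S(N)(=O)=O)cc2)C2=C(C(=O)CCC2)C1c1ccc(Cl)cc1Cl` carries a benzoyl on that amine nitrogen instead, and in this assay compound 2 gives 10 ug/mL. Going by the values given here, the single measured step is a 2.5-fold lower number from compound 1 to compound 2 (0.40 log units; beyond the scatter). Among the compounds with values here, on these two numbers compound 2 stands at the lower value, with compound 1 as its only and nearest neighbour.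

Compound 3 `COc1cc(C(=O)NC2=C(C#N)C(c3ccc(Cl)cc3Cl)C3=C(CCCC3=O)N2c2ccc(S(N)(=O)=O)cc2)cc(OC)c1OC` follows from compound 2 by one change: 3,4,5-trimethoxyphenyl in place of phenyl on a carbonyl carbon. Within the data shown here, no measured step bears directly on this change. The step from compound 1 to compound 2 concerns whether the benzoyl is present at all, not what sits on its ring, so it gives no guide to the direction or size of the new step. With nothing to point either way, the step expected in this assay is no change at the digits printed from compound 2 to compound 3 (within the scatter), which is no step beyond the scatter. Compound 3 is therefore estimated at 10 ug/mL, with a range from 4 ug/mL to 25 ug/mL.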

Compound 3, half-maximal inhibitory concentration: 60 ug/mL
Estimate against measurement, compound 3: 6.0-fold (0.78 log units) below; the whole stated range lies below it.
By their numbers in this assay, from the lowest: compound 2; then compound 1; then compound 3.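

In this assay the change to 3,4,5-trimethoxyphenyl on the carbonyl carbon gives a 6.0-fold higher number from compound 2 to compound 3 (0.78 log units; beyond the scatter) and so moves the read-out towards weaker inhibition. The earlier step spoke only to whether a benzoyl was present on the amine nitrogen, whereas this one shows that the group carried by that carbonyl carbon also matters: keeping the amide and swapping phenyl for a larger substituted ring does not preserve the number of compound 2. No accompanying measurement explains this shift.

The three methoxy groups arrive together in compound 3, so these compounds cannot show whether one methoxy alone would produce a similar step or whether the full trimethoxy pattern is needed. As far as these compounds go, it also remains open how a phenyl bearing a hydroxyl or an amine would read in this position, or whether replacing the ring with a small acetyl group on the same nitrogen would move the number in either direction.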